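The source may report more compounds than this note shows. Statements on the series, on what has been measured and on what is new or still open speak of the compounds shown alone.

Measured so far:
- compound 1 `Cc1ccc2cc(CN(Cc3ccc(Cl)cc3)Cc3ccc(C(C)C)cc3)c(=O)[nH]c2c1`: > 33000 nM
- compound 2 `Cc1ccc2[nH]c(=O)c(CN(CCCO)Cc3ccc(C(C)(C)C)cc3)cc2c1`: > 10000 nM
- compound 3 `CCc1ccc2[nH]c(=O)c(CN(CCCO)Cc3ccc(C(C)(C)C)cc3)cc2c1`: > 10000 nM

All three were tested in a toxicity assay on MDCK cells (Canis lupus familiaris) for cytotoxicity, read by crystal violet staining, with a stated time of 48 h; a higher number here means that more compound is tolerated, a lower number that less compound is tolerated. For compound 2 the result is only a limit, > 10000 nM, not a number. Compound 3 likewise reaches only a limit, > 10000 nM. Compound 1 also stops at a limit, > 33000 nM. Among the measured compounds shown here, because of this, the only single-point step among them, a step that the two limits leave unreadable from compound 2 to compound 3, cannot be sized: both of its ends sit at the limit of > 10000 nM in this assay, at which 2 of the 3 values shown sit. The third value sits at the limit of > 33000 nM in this assay, at which 1 of the 3 values shown sits. In short, nothing measured here rises above the scatter, and compound 2 stands where the other two stand, at a limit.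

The new compound, compound 4 `Cc1ccc2[nH]c(=O)c(CN(Cc3ccc(OCC(=O)O)cc3)Cc3ccc(C(C)(C)C)cc3)cc2c1`, differs from compound 2 by 4-(carboxymethoxy)phenyl in place of 2-hydroxyethyl on a saturated chain carbon bound to an amine nitrogen. For the measured compounds named here, no measured step speaks directly to this change; the one step available is unreadable, and all three compounds are tolerated up to the limit of this assay. The expected step is therefore a step that the limit leaves unreadable from compound 2 to compound 4, nothing beyond the scatter, with compound 4 most likely ending at a limit again. Compound 4 is thus estimated at 30000 nM, in a range from 10000 nM to 100000 nM.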

Compound 4, half-maximal cytotoxic concentration: > 10000 nM
Compound 4 was reported as a limit (the forecaster's own chance of this, stated with the estimate: 80%); the middle value lies beyond the limit too.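

In this assay compound 4 gives > 10000 nM, which is a limit and not a number. Among the compounds shown here, compound 2 also stops at a limit, so no step between compound 2 and compound 4 can be read: the limit of > 10000 nM in this assay, at which 3 of the 4 values shown sit. The compounds shown leave open the concentration at which any of them harms the cells, and whether this change of group alters tolerance at all.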